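Swapping a terminal chloro for hydroxy on the pyrazole chain

The source may hold more compounds than are shown below. What is called first, only, known or untested is meant among the compounds shown, and "the series" means these compounds.

Compound 1 `ClCCCc1cn[nH]c1` stands at the tight end of the three numbers measured in an assay for inhibition of alcohol dehydrogenase (Equus caballus), read by spectrophotometry, in the presence of a further agent that is not named here; on this read-out lower numbers stand for tighter binding and higher numbers for weaker binding: compound 1 gives 20 nM. For the measured compounds named here, compound 2 `OCc1cc[nH]n1` gives 150000 nM in this assay, and compound 3 `OCCCc1cc[nH]n1` gives 60000 nM; the step of a 2.5-fold lower number from compound 2 to compound 3 (0.40 log units; beyond the scatter) is the only measured step among them. Compound 4 `OCCCc1cn[nH]c1` differs from compound 1 by hydroxy in place of chloro on a saturated chain carbon, three bonds along the chain from an aromatic carbon. Going by the values given here, no measured step covers this exchange: compounds 2 and 3 carry hydroxy groups, but they differ from compound 1 in more than one place, so their weak binding cannot be attributed to the hydroxy group alone. The step from compound 2 to compound 3 concerns chain length, not the terminal group, and bears only indirectly on the change. With nothing to anchor the exchange, a loss of binding beyond the scatter is expected, on the grounds that the hydroxy-bearing compound 2 gives 150000 nM and compound 3 gives 60000 nM. Compound 4 is therefore expected at 200 nM, within 30 nM to 2000 nM, a step of a 10-fold higher number from compound 1 to compound 4 (1.00 log units; beyond the scatter).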

Compound 4, dissociation constant: 560 nM
For compound 4 the middle estimate is 2.8-fold (0.45 log units) below the measured one, and the stated range covers the measured number.
By their numbers in this assay, from the lowest: compound 1; then compound 4; then compound 3; then compound 2.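

With this result the exchange of chloro for hydroxy has a measured size in this assay: the binding falls by a 28-fold higher number from compound 1 to compound 4 (1.45 log units; beyond the scatter) at this saturated chain carbon, three bonds along the chain from an aromatic carbon. This is the only step shown that isolates the terminal group, which the earlier hydroxy compounds could not do, as each of them differed from compound 1 in more than one place. The loss is large but not complete, for compound 4 with its hydroxy group still gives 560 nM on this read-out.

Going by these compounds, whether a bromo group or an amine at the same chain end would bind closer to compound 1 or to compound 4 stays open. So does whether a longer chain ending in chloro would keep the tight binding of compound 1. Nothing measured here accounts for the size of this step.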